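From isopropyl to phenyl on a shared core

The source may report more compounds than this note shows. Statements on the series, on what has been measured and on what is new or still open speak of the compounds shown alone.

Measured in a functional assay on SW480 cells (Homo sapiens) for antiproliferative activity, read by MTT assay, with a stated time of 48 h; a higher number here means a weaker inhibitor, a lower number a stronger inhibitor:
- Compound 1 `CC(C)=CCC[C@]1(C)/C=C/[C@@H](OC(=O)C=C(C)C)[C@](C)(O)/C=C/C(=O)/C(CN2CCN(C)CC2)=C\C1`: 800 nM
- Compound 2 `CC(C)=CCC[C@]1(C)/C=C/[C@@H](OC(=O)C=C(C)C)[C@](C)(O)/C=C/[C@H](O)/C(CO)=C\C1`: > 40000 nM (a limit)
- Compound 3 `CC(C)=CCC[C@]1(C)/C=C/[C@@H](OC(=O)C(C)C)[C@](C)(O)/C=C/C(=O)/C(CO)=C\C1`: 8510 nM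

Compound 3 at 8510 nM holds the higher of the two actual numbers. Compound 1 at 800 nM lies lower, beyond the scatter. The entry for compound 2 is > 40000 nM and is a limit, not a number.

Compound 4 `CC(C)=CCC[C@]1(C)/C=C/[C@@H](OC(=O)c2ccccc2)[C@](C)(O)/C=C/C(=O)/C(CO)=C\C1` has phenyl in place of isopropyl on a carbonyl carbon and is otherwise compound 3. Among the compounds with values here, no measured pair shows this change, so only a small step in this assay is expected, not beyond the scatter, leaning towards a lower number. The expected step is a 1.4-fold lower number from compound 3 to compound 4 (0.15 log units; within the scatter) in this estimate. For compound 4 the estimated value is 6000 nM (expected range 2000 nM to 20000 nM).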

Compound 4, half-maximal inhibitory concentration: 10300 nM
Estimate against measurement, compound 4: 1.7-fold (0.23 log units) below; measured number inside the range.
By their numbers in this assay, from the lowest: compound 1; then compounds 3 and 4 (each within the scatter of the next). At a limit, above all of these: compound 2.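

In this assay the step reads a 1.2-fold higher number from compound 3 to compound 4 (0.08 log units; within the scatter) and is the first single-place comparison among these compounds. It shows that on this carbonyl carbon, benzoyl and isopropylcarbonyl cannot be told apart, even though phenyl brings a six-membered aromatic ring and more carbon atoms than isopropyl. Nothing given here bears on why the two compounds read alike.

On these data alone, whether an amine, a carboxylic acid or a longer chain on this carbonyl carbon would move the number remains open. So does whether phenyl would read the same way on compound 1.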